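The compounds below may be only part of what the source reports. "The series", "measured", "known", "first", "only" and "open" are said of these compounds alone.

Among the compounds with values here, in an ADME assay on HepG2 2.2.15 cells (Homo sapiens) for cytotoxicity (a higher number here means that more compound is tolerated, a lower number that less compound is tolerated), compound 2 `CCOCC(=O)OCCc1c(-c2ccccc2Cl)c2cc(Cl)ccc2[nH]c1=O` gives 130000 nM and so sits within the scatter of compound 1 `N#CCC(=O)OCCc1c(-c2ccccc2Cl)c2cc(Cl)ccc2[nH]c1=O` with 100000 nM as the only other measurement so far. Compound 3 `O=C(CCC1CCCCC1)OCCc1c(-c2ccccc2Cl)c2cc(Cl)ccc2[nH]c1=O` carries the change cyclohexylmethyl in place of ethoxy on a saturated chain carbon bound to a carbonyl carbon in which cyclohexylmethyl stands in place of ethoxy on a saturated chain carbon bound to a carbonyl carbon. Within the data shown here, the only measured step at this place is a 1.3-fold higher number from compound 1 to compound 2 (0.11 log units; within the scatter) with ethoxy in place of cyano. That step gives no sign yet that this assay responds to changes here. The entering group is larger and holds a ring, however, and a single step is thin evidence. The expected change is therefore a 1.4-fold lower number from compound 2 to compound 3 (0.16 log units; within the scatter) and no step beyond the scatter is expected. For compound 3 the estimate is 90000 nM with an expected range from 35000 nM to 220000 nM given the thin evidence.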

Compound 3, half-maximal cytotoxic concentration: 160000 nM
Beside the measured number, compound 3's estimate is 1.8-fold (0.25 log units) below it, within the range that was stated.
By their numbers in this assay, from the lowest: compounds 1, 2 and 3 (each within the scatter of the next).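

In this assay, cyclohexylmethyl in place of ethoxy on a saturated chain carbon bound to a carbonyl carbon gives a 1.2-fold higher number from compound 2 to compound 3 (0.09 log units; within the scatter) and the same group in place of cyano gives a 1.6-fold higher number from compound 1 to compound 3 (0.20 log units; within the scatter) with both steps within the scatter. This position has now taken a larger group holding a six-membered non-aromatic ring of carbon only, and the three compounds still cannot be told apart in this read-out. Nothing at hand explains why the numbers stay so close. Going by these compounds, whether a group of another kind at this place, such as an amine or a carboxylic acid, would move the number beyond the scatter remains open. Changes elsewhere on the shared core also remain open, since all three compounds differ only at this one place.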